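The source may hold more compounds than are shown below. What is called first, only, known or untested is meant among the compounds shown, and "the series" means these compounds.

Values in a functional assay on K562 cells (Homo sapiens) for inhibition, read by trypan blue exclusion, with a stated time of 72 h (on this read-out lower numbers stand for stronger inhibition and higher numbers for weaker inhibition), for the series so far:
- compound 1 `Cn1c(=O)c(S(=O)(=O)c2ccc(F)cc2F)cc2cnc(Nc3cccc4[nH]ccc34)nc21` gives 1500 nM
- compound 2 `Cn1c(=O)c(S(=O)(=O)c2ccc(F)cc2F)cc2cnc(Nc3ccc4occc4c3)nc21` gives 15000 nM
- compound 3 `Cn1c(=O)c(S(=O)(=O)c2ccc(F)cc2F)cc2cnc(Nc3ccncn3)nc21` gives 30000 nM

Compound 1 has the lowest number of the three in this assay and stands clear of both others, with a 10-fold higher number from compound 1 to compound 2 (1.00 log units; beyond the scatter) and a 20-fold higher number from compound 1 to compound 3 (1.30 log units; beyond the scatter) as its steps. The remaining pair shows a 2.0-fold higher number from compound 2 to compound 3 (0.30 log units; within the scatter) as its step.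

Compound 4 `COc1ccc(S(=O)(=O)c2cc3cnc(Nc4cccc5[nH]ccc45)nc3n(C)c2=O)cc1` is the next to be read, with 4-methoxyphenyl in place of 2,4-difluorophenyl on a sulfonyl sulfur. All three measured steps change the group on a nitrogen on an aromatic ring. None changes the group on the sulfonyl sulfur, so the data hold no direct measure of this change, neither its size nor its direction. Among the measured compounds shown here, compound 4 keeps the 1H-indol-4-yl of compound 1, which gives the lowest value so far (1500 nM). No step beyond the scatter is therefore expected in this assay, and the estimated step is small (a 1.5-fold lower number from compound 1 to compound 4 (0.18 log units; within the scatter)). Compound 4 is expected at 1000 nM (estimated range 200 nM to 5000 nM).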

Compound 4, half-maximal inhibitory concentration: 5000 nM
Compound 4: the middle estimate sits 5.0-fold (0.70 log units) below what was measured; measured number inside the range.
By their numbers in this assay, from the lowest: compound 1; then compound 4; then compounds 2 and 3 (each within the scatter of the next).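

In this assay, the group on the sulfonyl sulfur proves able to shift the read-out: with the 1H-indol-4-yl held fixed, 4-methoxyphenyl in place of 2,4-difluorophenyl gives a 3.3-fold higher number from compound 1 to compound 4 (0.52 log units; beyond the scatter) as the first step read at this position. The direction favours 2,4-difluorophenyl of these two groups, so this position joins the group on the aromatic-ring nitrogen as a place where a change moves the number beyond the scatter. No measurement in hand accounts for this step.

Still open, on these data alone, is which part of the exchange carries the step, the loss of the two fluorines or the arrival of the methoxy, which plain phenyl or 4-fluorophenyl on the sulfonyl sulfur could separate. Also open, as far as these compounds go, are how a carboxylic acid or an amine on that phenyl ring would read, and whether the step holds with 1-benzofuran-5-yl on the nitrogen.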